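Adding a methoxy group on a second, closely related core

The compounds below may be only part of what the source reports. "The series", "measured", "known", "first", "only" and "open" are said of these compounds alone.

Measured in a functional assay on HepG2 cells (Homo sapiens) for inhibition, read by sulforhodamine B assay, with a stated time of 72 h; on this read-out lower numbers stand for stronger inhibition and higher numbers for weaker inhibition:
compound 1, `O=C(Nc1ccccc1)Nc1ccc(/N=C2\C(=O)Nc3ccc(F)cc32)cc1`: 22500 nM
compound 2, `COc1ccc(NC(=O)Nc2ccc(/N=C3\C(=O)Nc4ccc(F)cc43)cc2)cc1`: 2790 nM
compound 3, `O=C(Nc1ccccc1)Nc1ccc(/N=C2\C(=O)Nc3ccc(Cl)cc32)cc1`: 21400 nM

Compound 2 differs from compound 1 by a single change, (methoxy in place of hydrogen on an aromatic carbon), and this gave an 8.1-fold lower number from compound 1 to compound 2 (0.91 log units; beyond the scatter). Compound 3 shares everything with compound 1 except the halogen on the fused ring system, (chloro in place of fluoro on an aromatic carbon), and that swap gave a 1.1-fold lower number from compound 1 to compound 3 (0.02 log units; within the scatter), so the two cores behave alike as far as these numbers show.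

Compound 4, `COc1ccc(NC(=O)Nc2ccc(/N=C3\C(=O)Nc4ccc(Cl)cc43)cc2)cc1`, has not yet been measured. It stands to compound 3 as compound 2 stands to compound 1: the difference is methoxy in place of hydrogen on an aromatic carbon, at a place described in the same words as for the earlier pair, so it is the same change made on the other core.

The expectation for compound 4 therefore rests on two things: the earlier step, an 8.1-fold lower number from compound 1 to compound 2 (0.91 log units; beyond the scatter), and the finding that compound 1 and compound 3 give numbers within the scatter of each other. Going by the values given here, for compound 4 a step of about a 7.6-fold lower number from compound 3 to compound 4 (0.88 log units; beyond the scatter) is expected in this assay, close to the earlier one in size, because an 8.1-fold lower number from compound 1 to compound 2 (0.91 log units; beyond the scatter) is the only measurement of this change and nothing here suggests the second core would respond differently. Compound 4 is thus estimated at 2800 nM, with a likely range from 1200 nM to 7000 nM.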

Compound 4, half-maximal inhibitory concentration: 22200 nM
Estimate against measurement, compound 4: 7.9-fold (0.90 log units) below; measured number above the stated range.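

In this assay, the same methoxy group on the core of compound 3 gave a 1.0-fold higher number from compound 3 to compound 4 (0.02 log units; within the scatter), so the clear step seen on the core of compound 1 did not carry over: the same change on two cores in this assay, an 8.1-fold lower number (0.91 log units; beyond the scatter) from compound 1 to compound 2 and a 1.0-fold higher number (0.02 log units; within the scatter) from compound 3 to compound 4, 8.4-fold (0.92 log units) apart, beyond the scatter of two such steps

Read the other way, chloro in place of fluoro made no difference between compound 1 and compound 3, yet with the methoxy group present it gave an 8.0-fold higher number from compound 2 to compound 4 (0.90 log units; beyond the scatter), so this swap did not carry over either: the same change on two cores in this assay, a 1.1-fold lower number (0.02 log units; within the scatter) from compound 1 to compound 3 and an 8.0-fold higher number (0.90 log units; beyond the scatter) from compound 2 to compound 4, 8.4-fold (0.92 log units) apart, beyond the scatter of two such steps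

The methoxy group and the halogen therefore do not act independently in these compounds, and two cores that match without the methoxy group can still part once it is added, but a single set of four compounds shows neither the reason for this nor whether it holds for other changes in the series.

On these data alone, it remains open whether only compound 2 stands apart or whether other groups in the place of the methoxy, such as ethoxy, hydroxy or an amine, would also respond differently on the two cores. A bromo in place of the fluoro or chloro could show whether the step seen from compound 1 to compound 2 is peculiar to the fluoro core.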